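Chloro for benzyloxy on the pendant aryl ring

The source may hold more compounds than are shown below. What is called first, only, known or untested is meant among the compounds shown, and "the series" means these compounds.

Among the measured compounds shown here, the three measured members are compound 1 `COc1ccc(C2=NN(C(=O)c3cccnc3Cl)C(c3ccc(Cl)cc3)C2)cc1`, compound 2 `COc1ccc(C2=NN(C(=O)c3cccnc3Cl)C(c3ccc(OCc4ccccc4)cc3)C2)cc1` and compound 3 `O=C(c1cncc(Br)c1)N1N=C(c2ccc(Cl)cc2)CC1c1ccc(OCc2ccccc2)cc1`. In a functional assay on WM 266-4 cells (Homo sapiens) for antiproliferative activity, read by MTT assay, with a stated time of 24 h (a lower number here means a stronger inhibitor of growth, a higher number a weaker inhibitor of growth), compound 1 gives 780 nM. In this assay compound 2 gives 9150 nM, and compound 3 gives 8130 nM. The values of compound 2 and compound 3 fall within the scatter of each other, so no order is drawn between them. Compound 1 and compound 2 differ in one place: chloro in place of benzyloxy on an aromatic carbon. In this assay that change produced a 12-fold lower number from compound 2 to compound 1 (1.07 log units; beyond the scatter). The cores of compound 2 and compound 3 differ in more than one place, and that difference is not broken down here; all that can be said is that their two values are close.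

Compound 4 `O=C(c1cncc(Br)c1)N1N=C(c2ccc(Cl)cc2)CC1c1ccc(Cl)cc1` has not yet been measured in this assay. It differs from compound 3 in one place: chloro in place of benzyloxy on an aromatic carbon. The place is described in the same words as for the pair compound 2 and compound 1, so this is the same change, now made on the core of compound 3. For the measured compounds named here, only one earlier instance of it exists, which limits confidence, but the step from compound 3 to compound 4 is expected to be an 11-fold lower number from compound 3 to compound 4 (1.04 log units; beyond the scatter) because a 12-fold lower number from compound 2 to compound 1 (1.07 log units; beyond the scatter) was seen for the identical change. Compound 4 is therefore expected to give about 750 nM. The range expected for compound 4 runs from 250 nM to 2500 nM.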

Compound 4, concentration for 50% growth inhibition: 6090 nM
For compound 4 the middle estimate is 8.1-fold (0.91 log units) below the measured one; the measured number lies above the stated range.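

On the second core, chloro in place of benzyloxy on an aromatic carbon gives a 1.3-fold lower number from compound 3 to compound 4 (0.13 log units; within the scatter), a step that stays within the scatter. The size of this change therefore does not carry from one core to the other in this assay: the same change on two cores in this assay, a 12-fold lower number (1.07 log units; beyond the scatter) from compound 2 to compound 1 and a 1.3-fold lower number (0.13 log units; within the scatter) from compound 3 to compound 4, 8.8-fold (0.94 log units) apart, beyond the scatter of two such steps

This does not show which part of the cores goes with the gap, since they differ in more than one place, and with only two instances it cannot be said whether the large step or the small one is more typical of the series.

The compounds shown leave open what other groups at this place would do on either core, for example an amine, a carboxylic acid or a longer chain in place of benzyloxy and chloro. Also open, going by these compounds, is how the change would behave on a core that carries only one of the differences between the two cores, which would be needed to tie the gap to a single place.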